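Replacing 2-Fluorophenyl with 3-Chlorophenyl on Compound 3

A few compounds are considered here, and "the series" means these few. Any claim that something is new, unique, unknown or untested is made for them only; others in the source may bear on it.

Compound 3 `Fc1cccc(-c2nc(Nc3ccccc3F)c3cc(F)ccc3n2)c1` stands at the edge of what a functional assay on U2OS cells (Homo sapiens) for cytotoxicity, read by MTT assay, with a stated time of 48 h (on this read-out higher numbers stand for weaker inhibition and lower numbers for stronger inhibition), can report: in this assay compound 3 gives > 50000 nM, which is a limit of the assay and not a number. Two measured comparisons reach compound 3. Compound 1 `COc1ccc(Nc2nc(-c3cccc(F)c3)nc3ccc(F)cc23)cc1` gives 32300 nM in this assay. Compound 2 `COc1ccccc1Nc1nc(-c2cccc(F)c2)nc2ccc(F)cc12` gives > 50000 nM in this assay, and that value too is a limit. The steps of an at least 1.5-fold higher number from compound 1 to compound 3 (0.18 log units; that floor lies within the scatter) and an at least 1.5-fold higher number from compound 1 to compound 2 (0.18 log units; that floor lies within the scatter) both run toward weaker inhibition, while a step that the two limits leave unreadable from compound 2 to compound 3 stays unreadable because of the limit of > 50000 nM in this assay, at which 2 of the 3 values shown sit. Compound 4 `Fc1cccc(-c2nc(Nc3cccc(Cl)c3)c3cc(F)ccc3n2)c1` differs from compound 3 by 3-chlorophenyl in place of 2-fluorophenyl on a nitrogen on an aromatic ring. Within the data shown here, no measured pair makes this exact change, so the step of an at least 1.2-fold lower number from compound 3 to compound 4 (0.09 log units; that floor lies within the scatter) is an estimate only, one that keeps compound 4 close to the limit where compound 3 sits, with a fair chance that only a limit is reported again. Compound 4 is therefore expected to give about 40000 nM in this assay, within a range from 12000 nM to 120000 nM.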

Compound 4, half-maximal inhibitory concentration: > 50000 nM
Compound 4 was reported as a limit (the forecaster's own chance of this, stated with the estimate: 50%); at least 1.2-fold (0.09 log units) between middle value and limit.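

The 3-chlorophenyl group on this nitrogen adds a third group that yields only a limit, after 2-methoxyphenyl and 2-fluorophenyl, so among the compounds shown only the 4-methoxyphenyl group of compound 1 gives a number in this assay. Among these compounds, the one readable step is an at least 1.5-fold higher number from compound 1 to compound 4 (0.18 log units; that floor lies within the scatter), and its floor does not separate the two compounds beyond the usual scatter. The steps to compound 4 from compound 2 and from compound 3 cannot be read, because both ends of each are limits: the limit of > 50000 nM in this assay, at which 3 of the 4 values shown sit.

As far as these compounds go, how far compound 2, compound 3 and compound 4 lie from one another beyond that limit remains open. Also open, from the compounds shown here alone, is whether a phenyl group carrying an amine or a carboxylic acid on this nitrogen would return a number rather than a limit.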